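The source may hold more compounds than are shown below. What is called first, only, known or untested is meant among the compounds shown, and "the series" means these compounds.

Compound 3 `Nc1ccccc1NC(=O)c1ccc(CSC(=S)N2CCN(c3ncccn3)CC2)cc1` gives 28.4% in a functional assay on MGC-803 cells (Homo sapiens) for antiproliferative activity, read by CCK-8 assay, with a stated time of 72 h, tested at 2 uM (on this read-out lower numbers stand for a weaker effect and higher numbers for a stronger effect at the one concentration tested), and stands highest of the three compounds measured. Its neighbours are compound 2 `Nc1ccccc1NC(=O)c1ccc(CSC(=S)N2CCN(Cc3ccncc3)CC2)cc1`, which gives 18.4%, and compound 1 `Nc1ccccc1NC(=O)c1ccc(CSC(=S)N2CCN(C3CCCCC3)CC2)cc1`, which gives 16.9%. The step of a number 11.5 percentage points higher from compound 1 to compound 3 (beyond the scatter) lies beyond the scatter and is modest; the step of a number 10 percentage points higher from compound 2 to compound 3 (within the scatter) stays within the scatter, so compound 3 and compound 2 cannot be ordered. The step of a number 1.5 percentage points higher from compound 1 to compound 2 (within the scatter) is likewise within the scatter.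

Compound 4 `Cc1ccc(N2CCN(C(=S)SCc3ccc(C(=O)Nc4ccccc4N)cc3)CC2)cc1` differs from compound 3 in one place: 4-methylphenyl in place of pyrimidin-2-yl on an amine nitrogen in a ring. Within the data shown here, all three measured steps change the group on an amine nitrogen in a ring, the same position touched here, and the only step beyond the scatter was the one from cyclohexyl to pyrimidin-2-yl. Among the measured compounds shown here, no measured compound carries 4-methylphenyl, so there is no direct step to lean on. For the measured compounds named here, since every exchange at this position so far has moved the number by little more than the scatter, the account expects compound 4 to sit near compound 3, with a small step downward of about a number 4.4 percentage points lower from compound 3 to compound 4 (within the scatter), not clearly beyond the scatter. The estimated value for compound 4 in this assay is therefore 24%, expected between 12% and 36%.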

Compound 4, a percentage reported as inhibition, at one concentration (the size of the read-out at that concentration, not a potency): 33.4%
The estimate for compound 4 lay 9.4 percentage points below the measured number, within the range that was stated.
By their numbers in this assay, from the lowest: compounds 1, 2, 3 and 4 (each within the scatter of the next, the first and the last beyond it).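

In this assay, putting 4-methylphenyl in place of pyrimidin-2-yl gives a number 5 percentage points higher from compound 3 to compound 4 (within the scatter), so at this position a six-membered aromatic ring of carbon only, with 0 hydrogen-bond acceptors, cannot be told apart from a ring with 2 nitrogen and 2 hydrogen-bond acceptors. Among these compounds, the same group gives a number 15 percentage points higher from compound 2 to compound 4 (beyond the scatter), the first step beyond the scatter away from (pyridin-4-yl)methyl, and a number 16.5 percentage points higher from compound 1 to compound 4 (beyond the scatter), a second step beyond the scatter away from cyclohexyl. Both pyrimidin-2-yl and 4-methylphenyl thus stand clear of cyclohexyl, but the split from (pyridin-4-yl)methyl is not clean: compound 3 goes against it, with a number 10 percentage points higher from compound 2 to compound 3 (within the scatter).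

No measurement shown here offers an explanation for these steps. As far as these compounds go, whether the methyl group of 4-methylphenyl plays any part stays open, as does what a plain phenyl, a 4-methoxyphenyl or a 4-chlorophenyl would give on this amine nitrogen, and these readings at a single concentration say nothing about potency.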